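Methyl groups on fused tetracyclic and pentacyclic indole esters

The compounds below may be only part of what the source reports. "The series", "measured", "known", "first", "only" and "open" are said of these compounds alone.

Measured so far:
Compound 1, `COC(=O)[C@@]1(C)CCC=C2[C@@H]1CC[C@@H](C)[C@]2(C)Cc1c[nH]c2ccc(C)cc12`, gives 15000 nM in a functional assay on SW1573 cells (Homo sapiens) for inhibition, read by sulforhodamine B assay, with a stated time of 48 h; a higher number here means a weaker inhibitor of growth, a lower number a stronger inhibitor of growth.
Compound 2, `COC(=O)[C@@]1(C)CCC=C2[C@@H]1CC[C@@H](C)[C@]2(C)Cc1c(C)[nH]c2ccc(C)cc12`, gives 18000 nM in this assay.
Compound 3, `COC(=O)[C@@]1(C)CC[C@@H]2C3=C1CC[C@@H](C)[C@]3(C)Cc1c2[nH]c2ccccc12`, gives 8300 nM in this assay.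

Compounds 1 and 2 share one core and differ by methyl in place of hydrogen on an aromatic carbon. That change made a 1.2-fold higher number from compound 1 to compound 2 (0.08 log units; within the scatter), so the two numbers are effectively the same. Compound 3 has a different core; the difference between the two cores is not broken down here. Its number in this assay lies within the scatter of compound 1 but beyond the scatter of compound 2, so only against compound 2 can it be called lower.

Compound 4, `COC(=O)[C@@]1(C)CC[C@@H]2C3=C1CC[C@@H](C)[C@]3(C)Cc1c2[nH]c2c(C)cccc12`, has not yet been measured. It differs from compound 3 by methyl in place of hydrogen on an aromatic carbon. This is the same kind of change as that from compound 1 to compound 2, but the place is not the same: in compound 2 the methyl enters a five-membered aromatic ring with one nitrogen, next to the ring nitrogen and next to the ring atom that bears a large group, whereas in compound 4 it enters a six-membered aromatic ring of carbon only, ortho to a fused ring and meta to a fused ring.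

Because the earlier methyl step gave a 1.2-fold higher number from compound 1 to compound 2 (0.08 log units; within the scatter), compound 4 is expected to stay close to compound 3, with an estimated step of a 1.1-fold higher number from compound 3 to compound 4 (0.06 log units; within the scatter) in this assay. The estimate for compound 4 is 9500 nM, expected to fall between 4000 nM and 22000 nM.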

Compound 4, concentration for 50% growth inhibition: 16000 nM
Compound 4: middle estimate off by 1.7-fold (0.23 log units), on the low side; low and high end bracket the measured number.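

In this assay, methyl in place of hydrogen on an aromatic carbon gave a 1.9-fold higher number from compound 3 to compound 4 (0.29 log units; within the scatter), so this step, like the earlier one, leaves the two numbers effectively the same. Set side by side, the two steps do not differ from one core to the other: the same change on two cores in this assay, a 1.2-fold higher number (0.08 log units; within the scatter) from compound 1 to compound 2 and a 1.9-fold higher number (0.29 log units; within the scatter) from compound 3 to compound 4, 1.6-fold (0.21 log units) apart, within the scatter of two such steps. Within these four compounds, then, the methyl change leaves growth inhibition effectively unchanged on both cores, but that rests on only two pairs, and the methyl stands in a different place in each: in a five-membered aromatic ring with one nitrogen in compound 2, and on an aromatic carbon of a six-membered aromatic ring of carbon only in compound 4, so the result does not show what a methyl in one and the same place would do on both cores.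

The compounds shown leave open whether a group other than methyl at these places, such as a longer chain, an amine or a carboxylic acid, would give a step beyond the scatter. They also leave open what would happen if the methyl ester shared by all four compounds gave way to a carboxylic acid or an amide.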